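Moving the Ring Substituent and Exchanging Chlorine for Methoxy

A few compounds are considered here, and "the series" means these few. Any claim that something is new, unique, unknown or untested is made for them only; others in the source may bear on it.

Values measured in an assay on HEK293 cells for displacement of a labelled ligand from metabotropic glutamate receptor 5 (Homo sapiens), with a stated time of 2 h; on this read-out higher numbers stand for weaker inhibition and lower numbers for stronger inhibition:
Compound 1, `O=C1c2ccc(C#Cc3ccccc3Cl)nc2CCN1C1CCCC1`: > 32000 nM, which is a limit of the assay and not a number.
Compound 2, `O=C1c2ccc(C#Cc3cccc(Cl)c3)nc2CCN1C1CCCC1`: 5230 nM.
Compound 3, `O=C1c2ccc(C#Cc3ccc(Cl)cc3)nc2CCN1C1CCCC1`: > 32000 nM, again only a limit.

Compound 3 therefore sits at the limit of > 32000 nM in this assay, at which 2 of the 3 values shown sit, so its binding is not resolved as a number; it can only be said to be weak on this read-out.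

The unmeasured compound 4, `COc1cccc(C#Cc2ccc3c(n2)CCN(C2CCCC2)C3=O)c1`, differs from compound 3 by 3-methoxyphenyl in place of 4-chlorophenyl on a triple-bonded carbon. For the measured compounds named here, two measured steps bear on this change. The step of an at least 6.1-fold higher number from compound 2 to compound 3 (0.78 log units; beyond the scatter) shows that carrying the chlorine on a 4-chlorophenyl ring rather than a 3-chlorophenyl ring gives a clearly weaker result, and the step of an at least 6.1-fold lower number from compound 1 to compound 2 (0.78 log units; beyond the scatter) shows the 3-chlorophenyl ring also beating the 2-chlorophenyl ring; the step from compound 1 to compound 3 cannot be read because both values are limits. Going by the values given here, compound 4 returns the substituent to the 3-substituted arrangement that compound 2 carries, but with methoxy in place of chlorine, a swap for which no measured step exists. A lower number is therefore expected for compound 4, of about the size an at least 3.5-fold lower number from compound 3 to compound 4 (0.55 log units; beyond the scatter), with wide uncertainty. The estimate for compound 4 in this assay is 9000 nM, within 2500 nM to 32000 nM.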

Compound 4, inhibition constant: > 32000 nM
Compound 4 ended at the assay's limit; the forecaster's own chance of this, stated with the estimate: 30%; middle value at least 3.5-fold (0.55 log units) away from the limit.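

In this assay, swapping chlorine for methoxy on the same ring carbon is a clear loss, giving an at least 6.1-fold higher number from compound 2 to compound 4 (0.78 log units; beyond the scatter). The earlier compounds showed only that the 3-chlorophenyl ring was the one ring of the three to give a readable number; compound 4 adds that the 3-methoxyphenyl ring does not share this, so among the compounds shown a readable value appears only with chlorine on the 3-substituted ring, as in compound 2. The steps linking compound 4 to compound 1 and to compound 3 cannot be read because both ends of each step are limits, not numbers, and the series now crowds at a single ceiling: the limit of > 32000 nM in this assay, at which 3 of the 4 values shown sit.

Going by these compounds, it remains open whether the loss is particular to methoxy or would also follow with another group in its place, such as the methyl of a 3-methylphenyl ring or the fluorine of a 3-fluorophenyl ring. Also open, on these data alone, is whether a second group on the 3-chlorophenyl ring, such as a fluorine, would move the value of compound 2, 5230 nM, in either direction.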